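One Methyl Added to a Strong Binder

The source may hold more compounds than are shown below. What is called first, only, known or untested is meant among the compounds shown, and "the series" means these compounds.

Measured so far:
- compound 1 `O=C(O)c1csc(SCCN2C(=O)CC[C@@H]2/C=C/[C@@H](O)Cc2cccc(-c3ccccc3)c2)n1`: 0.94 nM
- compound 2 `O=C(O)c1csc(SCCN2C(=O)CC[C@@H]2/C=C/[C@@H](O)Cc2cccc(-c3nc4ccccc4o3)c2)n1`: 0.12 nM

Both numbers come from an assay on CHO cells for displacement of a labelled ligand from prostaglandin E2 receptor EP4 subtype (Mus musculus), read by scintillation counting, with a stated time of 60 min; on this read-out higher numbers stand for weaker inhibition and lower numbers for stronger inhibition. For the measured compounds named here, the single measured step is a 7.8-fold lower number from compound 1 to compound 2 (0.89 log units; beyond the scatter). Going by the values given here, compound 2 therefore holds the lowest of the two numbers in this assay, and compound 1 is its only comparison.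

Compound 3 `Cc1ccc2oc(-c3cccc(C[C@H](O)/C=C/[C@H]4CCC(=O)N4CCSc4nc(C(=O)O)cs4)c3)nc2c1` differs from compound 2 by methyl in place of hydrogen on an aromatic carbon. Among the compounds with values here, no measured step bears directly on such a change: the one known step exchanges an entire ring system for another, whereas here a single carbon is added to the ring system already present. Without a comparable precedent, the sensible expectation is that a change this small leaves the number close to where compound 2 stands. Compound 3 is expected to show a step of no change at the digits printed from compound 2 to compound 3 (within the scatter) in this assay, that is, nothing beyond the usual scatter. The estimate for compound 3 is 0.12 nM, with a range from 0.05 nM to 0.35 nM.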

Compound 3, inhibition constant: 0.21 nM
The estimate for compound 3 lay 1.8-fold (0.24 log units) below the measured number; the range from low to high includes it.
By their numbers in this assay, from the lowest: compounds 2 and 3 (each within the scatter of the next); then compound 1.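

In this assay the methyl on the six-membered aromatic ring of the 1,3-benzoxazol-2-yl group brings a 1.8-fold higher number from compound 2 to compound 3 (0.24 log units; within the scatter) and so this position takes one added carbon without a change that can be told apart from repeat measurements. The advantage over phenyl also remains with the methyl present, as 5-methyl-1,3-benzoxazol-2-yl in place of phenyl gives a 4.5-fold lower number from compound 1 to compound 3 (0.65 log units; beyond the scatter) and this step lies beyond the scatter. Nothing available here explains why the added methyl makes so little difference. From the compounds shown here alone, whether this carbon accepts more than a methyl stays open, and an ethyl, a methoxy group, a chlorine atom or an amine there would test that. The compounds also leave open what a methyl would do on the other carbons of the same ring.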